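Replacing a Fluorophenyl with a Chlorophenyl: Clearance Outlook

The source may hold more compounds than are shown below. What is called first, only, known or untested is meant among the compounds shown, and "the series" means these compounds.

compound 1 `O=S(=O)(c1ccc(F)cc1)c1cnc2cc(Cl)c(F)cc2c1-c1ccc(Cl)cc1`: 0.01 mL/min
compound 2 `O=S(=O)(c1cc(F)cc(F)c1)c1cnc2c(F)cccc2c1-c1ccccc1F`: 0.09 mL/min
compound 3 `O=S(=O)(c1ccc(F)c(Cl)c1)c1cnc2c(F)cccc2c1-c1ccccc1F`: 1.39 mL/min

In an ADME assay on microsomes from liver (Homo sapiens) for metabolic stability, tested at 2.5 uM (on this read-out higher numbers stand for fast clearance and lower numbers for slow clearance), compound 1 gives 0.01 mL/min, compound 2 gives 0.09 mL/min and compound 3 gives 1.39 mL/min, the highest of the three. Among the compounds with values here, the only step measured so far is a 15-fold higher number from compound 2 to compound 3 (1.19 log units; beyond the scatter), and it concerns the group on the sulfonyl sulfur, not the ring changed here. Compound 4 `O=S(=O)(c1ccc(F)c(Cl)c1)c1cnc2c(F)cccc2c1-c1ccc(Cl)cc1` differs from compound 3 in one place: 4-chlorophenyl in place of 2-fluorophenyl on an aromatic carbon. Compound 1 also carries a 4-chlorophenyl at that place, yet it differs from compound 4 in the sulfonyl group and in the core halogens as well, so its low value cannot be assigned to this one change. Within the data shown here, no measured step bears directly on the change, and the expectation is therefore a step of a 1.4-fold lower number from compound 3 to compound 4 (0.14 log units; within the scatter), not beyond the scatter. Compound 4 is estimated at 1 mL/min in this assay, within 0.3 mL/min to 3.5 mL/min.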

Compound 4, intrinsic clearance in a liver preparation (reported as CLH), per the amount of preparation that the assay uses: 0.01 mL/min
Compound 4: middle estimate off by 100-fold (2.00 log units), on the high side; the measured number lies below the stated range.
By their numbers in this assay, from the lowest: compounds 1 and 4 (each within the scatter of the next); then compound 2; then compound 3.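

In this assay, 4-chlorophenyl in place of 2-fluorophenyl on this aromatic carbon gives a 140-fold lower number from compound 3 to compound 4 (2.14 log units; beyond the scatter) with nothing else altered. A change at this place alone can therefore carry a large step, which compound 1 could not show, as it differs from compound 4 in other places too. Nothing available accounts for the step.

Going by these compounds, whether the halogen or its place on the ring matters remains open, and 4-fluorophenyl or 2-chlorophenyl would separate the two. So does whether the step holds with 3,5-difluorophenyl on the sulfonyl sulfur.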